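The source may report more compounds than this note shows. Statements on the series, on what has been measured and on what is new or still open speak of the compounds shown alone.

Compound 1 `O=C(O)c1cccc(Cc2c(-c3ccccc3)nn3cc(C4CC4)ccc23)n1` gives 190 nM in a functional assay on cells for antagonist activity at prostaglandin E2 receptor EP1 subtype (Rattus norvegicus), read by fluorescence and calcium flux, with a stated time of 60 s; a lower number here means a stronger inhibitor, a higher number a weaker inhibitor.
Compound 2 `CSc1ccc2c(Cc3cccc(C(=O)O)n3)c(-c3ccccc3)nn2c1` gives 87 nM.
Compound 3 `COc1ccc(-c2nn3cc(Cl)ccc3c2Cc2cccc(C(=O)O)n2)cc1` gives 5400 nM.

Among these three, compound 3 gives the highest number and is therefore the weakest inhibitor; compound 1 comes nearest to it, compound 2 stands furthest away. Compound 4 `O=C(O)c1cccc(Cc2c(N3CCCC3)nn3cc(Cl)ccc23)n1` keeps the core of compound 3 and differs from it in one place: pyrrolidin-1-yl in place of 4-methoxyphenyl on an aromatic carbon. Among the measured compounds shown here, the only measured step, a 2.2-fold lower number from compound 1 to compound 2 (0.34 log units; beyond the scatter), concerns another place on the shared core, so it says little about this exchange, and no measured compound carries pyrrolidin-1-yl. Compounds 1 and 2 lack the 4-methoxyphenyl group and give much lower numbers than compound 3, though they also differ from it elsewhere. The number for compound 4 is expected to fall by a 3.6-fold lower number from compound 3 to compound 4 (0.56 log units; beyond the scatter). The estimate for compound 4 is 1500 nM, with a range from 200 nM to 9000 nM.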

Compound 4, half-maximal inhibitory concentration: 1800 nM
Estimate against measurement, compound 4: 1.2-fold (0.08 log units) below; measured number inside the range.
By their numbers in this assay, from the lowest: compound 2; then compound 1; then compound 4; then compound 3.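

In this assay, the aromatic carbon of the five-membered aromatic ring tolerates a non-aromatic ring as well as an aromatic one: pyrrolidin-1-yl in place of 4-methoxyphenyl gives a 3.0-fold lower number from compound 3 to compound 4 (0.48 log units; beyond the scatter), a modest step toward stronger inhibition. The exchange replaces a six-membered aromatic ring of carbon only with a smaller non-aromatic ring holding a nitrogen, so several features change at once. No measurement here explains the step.

Which of those features matters remains open. So does how an open-chain dimethylamino group or a morpholin-4-yl ring would behave at this position on the same core.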